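Lengthening the amide substituent from methyl to propyl

The compounds below may be only part of what the source reports. "The series", "measured", "known", "first", "only" and "open" are said of these compounds alone.

Measured so far:
Compound 1 `Nc1c(C(=O)N/N=C/c2ccccc2)oc2nc(-c3ccccc3)cc(C(F)(F)F)c12` gives 70000 nM.
Compound 2 `CNC(=O)c1oc2nc(-c3ccccc3)cc(C(F)(F)F)c2c1N` gives 62000 nM.

Both values come from an ADME assay on HEK293 cells (Homo sapiens) for antiproliferative activity, read by MTT assay; on this read-out higher numbers stand for weaker inhibition and lower numbers for stronger inhibition. Among the compounds with values here, compound 2 stands at the lowest of the two numbers, but its only neighbour is close: the step of a 1.1-fold lower number from compound 1 to compound 2 (0.05 log units; within the scatter) stays within the scatter, so the two compounds cannot be ranked against each other. That step is also the only measured one, and it changes the substituent on the amide-type nitrogen without moving the number noticeably.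

Compound 3 `CCCNC(=O)c1oc2nc(-c3ccccc3)cc(C(F)(F)F)c2c1N` differs from compound 2 by ethyl in place of hydrogen on a saturated chain carbon bound to an amide-type nitrogen. This again alters only the substituent on the amide-type nitrogen. With a single measured step, itself within the scatter, bearing on this position, there is no basis to expect a change beyond the scatter in this assay. Compound 3 is therefore estimated at 60000 nM, between 25000 nM and 150000 nM, a step of a 1.0-fold lower number from compound 2 to compound 3 (0.01 log units; within the scatter) that is expected to be negligible.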

Compound 3, half-maximal inhibitory concentration: 81000 nM
Estimate against measurement, compound 3: 1.4-fold (0.13 log units) below, and the stated range covers the measured number.
By their numbers in this assay, from the lowest: compounds 2, 1 and 3 (each within the scatter of the next).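

Extending the chain on the amide-type nitrogen, methyl to propyl, gives a 1.3-fold higher number from compound 2 to compound 3 (0.12 log units; within the scatter) in this assay and is the first measured change of chain length at this position. Swapping the larger group on that nitrogen for propyl gives a 1.2-fold higher number from compound 1 to compound 3 (0.06 log units; within the scatter) and so adds a second comparison that cannot be told apart from no change. Across these three substituents, then, the position has shown no measurable response in this read-out, and no measurement at hand offers an explanation for that.

On these data alone, it remains open whether a much longer chain, or a chain ending in an amine or a carboxylic acid, would move the number beyond the scatter. Also open, as far as these compounds go, is whether changing the shared core elsewhere, rather than this amide substituent, would have any larger effect.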